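Swapping an aminoethyl amide for a methylazetidinyl amide

A few compounds are considered here, and "the series" means these few. Any claim that something is new, unique, unknown or untested is made for them only; others in the source may bear on it.

Three measured compounds share one core and differ only in the group on the amide nitrogen. Compound 1 `CNC(=O)c1cc(-c2ccc(NS(=O)(=O)c3cccc(Cl)c3Cl)cc2)nc2[nH]ncc12` carries a methyl there and in an assay for inhibition of serine/threonine-protein kinase Sgk1 (Homo sapiens), with stated times of 30 min and 60 min, in the presence of a further agent that is not named here (on this read-out higher numbers stand for weaker inhibition and lower numbers for stronger inhibition), compound 1 gives 929 nM. Compound 2 `CC(C)NC(=O)c1cc(-c2ccc(NS(=O)(=O)c3cccc(Cl)c3Cl)cc2)nc2[nH]ncc12` carries an isopropyl and in this assay compound 2 gives 17600 nM. Compound 3 `NCCNC(=O)c1cc(-c2ccc(NS(=O)(=O)c3cccc(Cl)c3Cl)cc2)nc2[nH]ncc12` carries a 2-aminoethyl group. In this assay compound 3 gives < 1 nM, which is a limit of the assay and not a number (the limit of < 1 nM in this assay, at which 1 of the 3 values shown sits), so compound 3 stands at the floor of what was measured. Every step between these compounds is large: a 19-fold higher number from compound 1 to compound 2 (1.28 log units; beyond the scatter), an at least 920-fold lower number from compound 1 to compound 3 (2.96 log units; beyond the scatter) and an at least 17000-fold lower number from compound 2 to compound 3 (4.24 log units; beyond the scatter).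

Compound 4 `CN1CC(NC(=O)c2cc(-c3ccc(NS(=O)(=O)c4cccc(Cl)c4Cl)cc3)nc3[nH]ncc23)C1` has not yet been measured. It differs from compound 3 by 1-methylazetidin-3-yl in place of 2-aminoethyl on an amide-type nitrogen. The measured steps show that this position moves the read-out strongly in both directions, and compound 4 keeps one acceptor but gives up the donor of compound 3. A moderate weakening is therefore expected, an at least 8.0-fold higher number from compound 3 to compound 4 (0.90 log units; beyond the scatter), with compound 4 estimated at 8 nM, within a range from 1 nM to 80 nM.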

Compound 4, half-maximal inhibitory concentration: < 1 nM
Compound 4 gave a limit, no number (the forecaster's own chance of this, stated with the estimate: 20%); middle value at least 8.0-fold (0.90 log units) away from the limit.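

The 1-methylazetidin-3-yl group is a ring with no hydrogen-bond donor, yet it gives an at least 920-fold lower number from compound 1 to compound 4 (2.96 log units; beyond the scatter) and an at least 17000-fold lower number from compound 2 to compound 4 (4.24 log units; beyond the scatter), so a donor on this group is not needed for strong inhibition here. In this assay compound 4 gives < 1 nM, which is a limit of the assay and not a number. The step between compound 3 and compound 4 cannot be read, since both sit at the same floor: the limit of < 1 nM in this assay, at which 2 of the 4 values shown sit.

How strong each of these two compounds really is stays hidden under that limit. From the compounds shown here alone, it also remains open whether the nitrogen in these groups is what counts, which a cyclobutyl group, a ring without nitrogen, or a 2-hydroxyethyl chain on the amide nitrogen could test.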